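From Cyclopropyl to Hydroxymethyl: A Permeability Estimate

The source may report more compounds than this note shows. Statements on the series, on what has been measured and on what is new or still open speak of the compounds shown alone.

Measured in an ADME assay on LLC-PK1 cells (Sus scrofa) for permeability, read by LC-MS, with a stated time of 2 h, tested at 5 uM; on this read-out lower numbers stand for lower permeability and higher numbers for higher permeability:
Compound 1 `COc1cc2c(cn1)Oc1ccc(NC(=O)c3ccc(Cl)cn3)cc1[C@@]21COC(N)=N1`: 25 nm/s
Compound 2 `NC1=N[C@@]2(CO1)c1cc(-c3cncc(C#CC4CC4)c3)ccc1Oc1cnc(C3=CCOCC3)cc12`: 13 nm/s

Compound 2, with 13 nm/s, lies within the usual scatter of compound 1, with 25 nm/s, so these two values cannot be ranked. Compound 3 `NC1=N[C@@]2(CO1)c1cc(-c3cncc(C#CCO)c3)ccc1Oc1cnc(C3=CCOCC3)cc12` has not yet been measured. It differs from compound 2 by a single change, hydroxymethyl in place of cyclopropyl on a triple-bonded carbon. Among the compounds with values here, no measured pair shows this change on its own, so any forecast is uncertain. In this assay a small decrease is expected, nothing beyond the scatter, and the expected step is a 1.3-fold lower number from compound 2 to compound 3 (0.11 log units; within the scatter). For compound 3 the estimated value is 10 nm/s, with a range of 4 nm/s to 25 nm/s.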

Compound 3, apparent permeability: 15 nm/s
Compound 3: middle estimate off by 1.5-fold (0.18 log units), on the low side; low and high end bracket the measured number.
By their numbers in this assay, from the lowest: compounds 2, 3 and 1 (each within the scatter of the next).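

Measured in this assay the swap gives a 1.2-fold higher number from compound 2 to compound 3 (0.06 log units; within the scatter) and so leaves the two compounds unranked. Within the data shown here, this is the only pair here that changes this position alone, and it shows that hydroxymethyl, with its hydrogen-bond donor and acceptor, can replace the cyclopropyl ring on this triple-bonded carbon without a step beyond the scatter. Nothing available explains this result. As far as these compounds go, whether an amine or a carboxylic acid at the same place would also stay within the scatter remains open. So does the reading for a longer chain ending in hydroxyl.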